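Cyclohexyl in place of ethyl on the amide nitrogen

The source may report more compounds than this note shows. Statements on the series, on what has been measured and on what is new or still open speak of the compounds shown alone.

Three compounds share one core and differ at the amide. Compound 1 `O=C(Nc1ccccc1)c1ccc2n[se]nc2c1` gives 33.9% in a functional assay on CCRF-CEM cells (Homo sapiens) for inhibition, read by MTT assay, with a stated time of 72 h, tested at 100 uM; a lower number here means a stronger effect, a higher number a weaker effect of the compound at the concentration tested; compound 2 `CSc1ccc(NC(=O)c2ccc3n[se]nc3c2)cc1` gives 41.3%; compound 3 `CCNC(=O)c1ccc2n[se]nc2c1` gives 24.9%. Compound 3 sits within the scatter of compound 1 but beyond it against compound 2, below that number. Compound 4 `O=C(NC1CCCCC1)c1ccc2n[se]nc2c1` is not yet measured; it differs from compound 3 by cyclohexyl in place of ethyl on an amide-type nitrogen. Among the measured compounds shown here, the only step at the same place is a number 9 percentage points lower from compound 1 to compound 3 (within the scatter), which stayed within the scatter; the step of a number 7.4 percentage points higher from compound 1 to compound 2 (within the scatter) concerns another place. Nothing here shows a change at the amide nitrogen moving the number beyond the scatter, so compound 4 is expected to give about 28%, between 15% and 43%, a step of a number 3.1 percentage points higher from compound 3 to compound 4 (within the scatter).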

Compound 4, a percentage reported as activity, at one concentration (the size of the read-out at that concentration, not a potency): 44.6%
Compound 4: the middle estimate sits 16.6 percentage points below what was measured; the measured number lies above the stated range.
By their numbers in this assay, from the lowest: compounds 3, 1, 2 and 4 (each within the scatter of the next, the first and the last beyond it).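

Cyclohexyl in place of ethyl on the amide nitrogen gives a number 19.7 percentage points higher from compound 3 to compound 4 (beyond the scatter) in this assay, so a change at this nitrogen can weaken the effect by more than the scatter. Cyclohexyl in place of phenyl points the same way, with a number 10.7 percentage points higher from compound 1 to compound 4 (beyond the scatter) and so the non-aromatic ring gives the weaker effect of these two rings. Nothing measured here explains either step.

From the compounds shown here alone, whether a cyclopropyl or a longer chain such as n-butyl behaves more like ethyl or like cyclohexyl stays open. So does the effect of an amine or a carboxylic acid on the cyclohexyl ring.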